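This account rests on a few compounds, and the source may have more. Where it says the series, first, only, none or still open, it means among the compounds named here.

In a functional assay on HCT-116 cells (Homo sapiens) for antiproliferative activity (on this read-out higher numbers stand for weaker inhibition and lower numbers for stronger inhibition), compound 3 `CC(=O)N1CCc2c(C)c3c(n2-c2ccc(C(N)=O)c(c2)N[C@@H](C)[C@H](C)C1)CC(C)(C)CC3=O` gives 24 nM, within the scatter of compound 2 `CC(=O)N1CCCc2c(C)c3c(n2-c2ccc(C(N)=O)c(c2)N[C@@H](C)[C@@H]1C)CC(C)(C)CC3=O` at 27 nM. Compound 1 `Cc1c2c(n3c1CCN(C(=O)[C@H](C)N)CC[C@H](C)Nc1cc-3ccc1C(N)=O)CC(C)(C)CC2=O` stands at 314 nM, weaker than both and beyond the scatter. Compound 4 `Cc1c2c(n3c1CCN(C(=O)CN)C[C@@H](C)[C@H](C)Nc1cc-3ccc1C(N)=O)CC(C)(C)CC2=O` departs from compound 3 by one change: amino in place of hydrogen on a saturated chain carbon bound to a carbonyl carbon. For the measured compounds named here, no measured step isolates this change. Going by the values given here, compound 1 also carries an amino group on such a carbon, though it differs elsewhere too, and its 314 nM is the only guide. A move toward weaker inhibition in this assay, beyond the scatter, is therefore expected. The estimated step is a 3.5-fold higher number from compound 3 to compound 4 (0.55 log units; beyond the scatter). For compound 4 the expected value is 85 nM, with an estimated range of 28 nM to 280 nM.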

Compound 4, half-maximal inhibitory concentration: 216 nM
For compound 4 the middle estimate is 2.5-fold (0.41 log units) below the measured one; low and high end bracket the measured number.
By their numbers in this assay, from the lowest: compounds 3 and 2 (each within the scatter of the next); then compounds 4 and 1 (each within the scatter of the next).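

Amino in place of hydrogen on a saturated chain carbon bound to a carbonyl carbon, read as acetyl to (aminomethyl)carbonyl, weakens inhibition in this assay by a 9.0-fold higher number from compound 3 to compound 4 (0.95 log units; beyond the scatter) as the only measured step at this position. The loss is now tied to this single change and no longer rests on a compound that differs elsewhere too. Nothing available offers an explanation for the size of this step.

From the compounds shown here alone, whether hydroxyl, dimethylamino or a carboxylic acid on this carbon would give a similar loss stays open. Also open, going by these compounds, is whether a longer chain carrying the amine would behave the same way.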